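A few compounds are considered here, and "the series" means these few. Any claim that something is new, unique, unknown or untested is made for them only; others in the source may bear on it.

Compound 1 `Cc1n[nH]c2ccc(-c3nc4cnc(N5CCN(C)CC5)cn4c3Nc3ccc(Cl)cc3)cc12`: 83.7%
Compound 2 `Cc1n[nH]c2ccc(-c3nc4cnc(N5CCC(C)CC5)cn4c3Nc3ccc(Cl)cc3)cc12`: 28%
Compound 3 `Cc1n[nH]c2ccc(-c3nc4cnc(N5CCN(C)CC5)cn4c3Nc3ccc(I)cc3)cc12`: 0%

In a functional assay on MV4-11 cells (Homo sapiens) for inhibition, with a stated time of 120 h, tested at 10 uM (a higher number here means more inhibition at the concentration tested (going by the name of the read-out), a lower number less inhibition), compound 1 stands highest of the three numbers, with both steps away from it beyond the scatter: a number 55.7 percentage points lower from compound 1 to compound 2 (beyond the scatter) and a number 83.7 percentage points lower from compound 1 to compound 3 (beyond the scatter). Compound 4 `Cc1n[nH]c2ccc(-c3nc4cnc(N5CCN(C)CC5)cn4c3Nc3ccc(Cl)cc3F)cc12` differs from compound 1 in one place: fluoro in place of hydrogen on an aromatic carbon. Neither measured step adds a group to the 4-chlorophenyl ring; one swaps chloro for iodo, the other replaces the 4-methylpiperazin-1-yl group. Both show large losses from single changes, so compound 1 appears sensitive, but nothing measured speaks to an added fluoro. Compound 4 is therefore expected to remain fairly high, with an estimated step of a number 13.7 percentage points lower from compound 1 to compound 4 (beyond the scatter). The estimate for compound 4 is 70%, between 20% and 95%.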

Compound 4, a percentage reported as inhibition, at one concentration (the size of the read-out at that concentration, not a potency): 0%
The estimate for compound 4 lay 70 percentage points above the measured number; measured number below the stated range.
By their numbers in this assay, from the lowest: compounds 3 and 4 (each within the scatter of the next); then compound 2; then compound 1.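

In this assay, adding one fluoro to the 4-chlorophenyl ring, ortho to a large group, gives a number 83.7 percentage points lower from compound 1 to compound 4 (beyond the scatter), so this ring carbon, untouched by the earlier changes, is also sensitive, even to a single added atom. Between the 4-chloro-2-fluorophenyl and 4-iodophenyl groups there is no change at the digits printed from compound 3 to compound 4 (within the scatter), so two different edits of this ring give the same reading. Nothing measured here accounts for the loss. The compounds shown leave open whether a methoxy or hydroxyl group at this carbon would restore inhibition, and whether fluoro elsewhere on the ring would be accepted.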